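A few compounds are considered here, and "the series" means these few. Any claim that something is new, unique, unknown or untested is made for them only; others in the source may bear on it.

Measured so far:
compound 1 `CCC1=C(O)c2c(oc(-c3ccccc3C)cc2=O)C(CC)(CC)C1=O`, 40.9 uM
compound 2 `CCC1=C(O)c2c(oc(-c3ccc(C)c(C)c3)cc2=O)C(CC)(CC)C1=O`, 35.5 uM

In a functional assay on KB cells (Homo sapiens) for antiproliferative activity, read by sulforhodamine B assay, with a stated time of 3 days (on this read-out lower numbers stand for an effect already at smaller amounts and higher numbers for an effect only at larger amounts of compound), compound 1 gives 40.9 uM and compound 2 gives 35.5 uM. Among the measured compounds shown here, the only step between measured compounds is a 1.2-fold lower number from compound 1 to compound 2 (0.06 log units; within the scatter), so the two values are indistinguishable within the usual scatter. Compound 2 has the lowest of the two numbers, but its nearest neighbour, compound 1, lies within the scatter of it, so no order between them can be claimed.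

Compound 3 `CCC1=C(O)c2c(oc(-c3cc(C)ccc3C)cc2=O)C(CC)(CC)C1=O` has not yet been measured in this assay. It differs from compound 2 in one place: 2,5-dimethylphenyl in place of 3,4-dimethylphenyl on an aromatic carbon. For the measured compounds named here, the step from compound 1 to compound 2 is the only measured step that bears on this change, since it also moves methyl groups around the same phenyl ring, and it stayed within the scatter. On that basis no step beyond the scatter is expected in this assay for compound 3, in either direction; the step from compound 2 to compound 3 is estimated as a 1.1-fold higher number from compound 2 to compound 3 (0.03 log units; within the scatter). Compound 3 is expected to give about 38 uM in this assay, with a range from 18 uM to 80 uM.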

Compound 3, concentration for half-maximal effect: 14.5 uM
Estimate against measurement, compound 3: 2.6-fold (0.42 log units) above; the whole stated range lies above it.
By their numbers in this assay, from the lowest: compound 3; then compounds 2 and 1 (each within the scatter of the next).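

In this assay the arrangement of the methyl groups on the phenyl ring turns out to matter: with the same atoms, 2,5-dimethylphenyl in place of 3,4-dimethylphenyl gives a 2.4-fold lower number from compound 2 to compound 3 (0.39 log units; beyond the scatter) as a modest step, whereas the earlier exchange on this ring stayed within the scatter. Methyl in place of hydrogen on the phenyl ring of compound 1 gives a 2.8-fold lower number from compound 1 to compound 3 (0.45 log units; beyond the scatter) as a step of similar modest size, yet compound 2, which also carries two methyl groups, stays within the scatter of compound 1, so the number of methyl groups alone does not set the value among these three compounds. Nothing given here explains why this arrangement differs from the other.

The compounds shown leave open whether a single methyl group in another place on the ring would give a number like that of compound 3, and whether larger or different groups, such as ethyl, methoxy or chlorine, in the places held by the two methyl groups of 2,5-dimethylphenyl would lower it further. They also leave open whether the same exchange would have a similar effect if the ethyl groups on the shared core were replaced by other chains.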